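A Methoxy for Fluoro Swap at the Cytotoxicity Limit

The compounds below may be only part of what the source reports. "The series", "measured", "known", "first", "only" and "open" are said of these compounds alone.

Three compounds from this series share a propenamide arm on a five-membered heteroaromatic ring, and none of them reaches a measurable number in a functional assay on T-24 cells (Homo sapiens) for cytotoxicity, read by CCK-8 assay, with a stated time of 24 h; on this read-out lower numbers stand for stronger inhibition and higher numbers for weaker inhibition. Compound 1, `C=C1CCC(c2csc(/C=C(\C)C(N)=O)c2)CC1`, gives only the assay limit of > 50000 nM in this assay. Compound 2, `C/C(=C\c1cc(C2=CCCC2)co1)C(N)=O`, likewise gives only the limit of > 50000 nM in this assay. Compound 3, `C/C(=C\c1cc(-c2ccc(F)cc2)cs1)C(N)=O`, gives the limit of > 50000 nM in this assay, so its standing can be told only as a limit and not as a number, and it sits alongside the other two values, which are also limits: the limit of > 50000 nM in this assay, at which 3 of the 3 values shown sit.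

Compound 4, `COc1ccc(-c2csc(/C=C(\C)C(N)=O)c2)cc1`, differs from compound 3 in one place: methoxy in place of fluoro on an aromatic carbon. Among the compounds with values here, no measured step between any two of the three compounds exists, so no step of known size can guide the expectation. With every value shown resting at the limit, the expected step that the limit leaves unreadable from compound 3 to compound 4 is none beyond the scatter, and it is expected that compound 4 will most likely also return only a limit. The estimate for compound 4 in this assay is 60000 nM, with a range from 20000 nM to 200000 nM.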

Compound 4, half-maximal inhibitory concentration: > 50000 nM
Compound 4: no number, only a limit; the forecaster's own chance of this, stated with the estimate: 85%; the middle value lies beyond the limit too.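

Within the data shown here, compound 3 and compound 4 both return only a limit in this assay, so no step between them can be read, in size or in direction: the limit of > 50000 nM in this assay, at which 4 of the 4 values shown sit.

The compounds shown leave open whether any member of this series reaches a measurable number in this assay, and how methoxy in place of fluoro on an aromatic carbon would shift such a number.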